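Distal aryl variation and acid dissociation in the series

The compounds below may be only part of what the source reports. "The series", "measured", "known", "first", "only" and "open" are said of these compounds alone.

Compound 1 `COc1cccc(CNCCCNc2ccnc3cc(Cc4ccc(F)cc4)ccc23)c1O` — a physicochemical assay for acid dissociation: 9.47
Compound 2 `COc1cccc(CNCCCNc2ccnc3cc(Cc4ccc(F)cc4Cl)ccc23)c1O` — 9.47
Compound 3 `COc1cccc(CNCCCNc2ccnc3cc(Cc4cc(C)cc(C)c4)ccc23)c1O` — not yet measured

Compound 2 stands level with compound 1 at the digits shown; the single measured step, no change at the digits printed from compound 1 to compound 2 (within the scatter), is the only comparison available, and it lies within the scatter. Compound 3 differs from compound 2 in the ring that hangs from the saturated chain carbon bound to an aromatic carbon: 3,5-dimethylphenyl in place of 2-chloro-4-fluorophenyl on a saturated chain carbon bound to an aromatic carbon. This is the same part of the molecule that was altered between compound 1 and compound 2, and that alteration left the acid dissociation constant unchanged within the scatter. The atoms whose proton dissociation is being read are not touched by the present exchange either. On that basis compound 3 is expected to show no step beyond the scatter, that is, no change at the digits printed from compound 2 to compound 3 (within the scatter) is expected to be essentially nil. The estimate for compound 3 is therefore 9.47, with a range of 9.2 to 9.75 that allows for the usual spread of repeated measurements.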

Compound 3, acid dissociation constant: 9.47
Compound 3: the middle estimate sits on the measured number at the digits printed; measured number inside the range.
By their numbers in this assay, from the lowest: compounds 1, 2 and 3 (each within the scatter of the next).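

In this assay, replacing 2-chloro-4-fluorophenyl with 3,5-dimethylphenyl on a saturated chain carbon bound to an aromatic carbon gives no change at the digits printed from compound 2 to compound 3 (within the scatter), and replacing 4-fluorophenyl with the same group gives no change at the digits printed from compound 1 to compound 3 (within the scatter). Earlier, this place had shown only the effect of chloro in place of hydrogen on an aromatic carbon; now both halogens leave together and a group of 8 carbon atoms enters, with the same count of 8 heavy atoms as the group it replaces, and the read-out still shows no step beyond the scatter. No separate measurement bears on why the read-out holds across these exchanges.

All the groups shown at this place are phenyl rings carrying only halogen or methyl substituents, so the compounds leave open whether this assay would hold with an amine or a carboxylic acid on the ring. Also open, from the compounds shown here alone, is whether it would hold with a longer chain in place of the saturated chain carbon, or with an exchange made outside this part of the molecule, in the shared core.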